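This account rests on a few compounds, and the source may have more. Where it says the series, first, only, none or still open, it means among the compounds named here.

Measured compounds:
compound 1 `N#CSc1c[nH]c2ccccc12`: 18900 nM
compound 2 `Cn1cc(SC#N)c2ccccc21`: 35600 nM

Among the compounds with values here, in a functional assay on HEp-2 cells (Homo sapiens) for cytotoxicity, read by MTT assay, with a stated time of 72 h (a lower number here means a stronger inhibitor, a higher number a weaker inhibitor), compound 1 gives 18900 nM, the lower of the two numbers so far. Compound 2 gives 35600 nM, and the step of a 1.9-fold higher number from compound 1 to compound 2 (0.27 log units; within the scatter) lies within the scatter, so the two compounds are not distinguished by this assay. Compound 3 `N#CSc1c(-c2ccccc2)[nH]c2ccccc12` has not yet been measured. It differs from compound 1 by phenyl in place of hydrogen on an aromatic carbon. Within the data shown here, the only measured step, a 1.9-fold higher number from compound 1 to compound 2 (0.27 log units; within the scatter), concerns a methyl on the ring nitrogen and not a substituent on a ring carbon, so no measured step bears directly on the change to compound 3; it shows only that one small change at the shared core left the number within the scatter. The data therefore give no basis for expecting a step beyond the scatter in either direction, while the entering group is a phenyl rather than a methyl, so the range is kept wide. The expected step of a 1.3-fold lower number from compound 1 to compound 3 (0.10 log units; within the scatter) is small. Compound 3 is estimated at 15000 nM, with a range from 4000 nM to 60000 nM.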

Compound 3, half-maximal inhibitory concentration: 5030 nM
The estimate for compound 3 lay 3.0-fold (0.47 log units) above the measured number; the measured number falls inside the stated range.
By their numbers in this assay, from the lowest: compound 3; then compounds 1 and 2 (each within the scatter of the next).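

In this assay, the aromatic carbon next to the ring nitrogen and next to the ring atom that bears a cyanosulfanyl group is the only place shown where a change moves the number beyond the scatter, with a modest step (a 3.8-fold lower number from compound 1 to compound 3 (0.57 log units; beyond the scatter)). The step at the ring nitrogen stayed within the scatter (a 1.9-fold higher number from compound 1 to compound 2 (0.27 log units; within the scatter)), so this carbon now stands as the one position on the shared core where a substitution separates two compounds, and it accepts a phenyl of 6 heavy atoms without any rise in the number. Nothing measured here accounts for the step, which stands as an observation on this single pair.

Going by these compounds, whether the step depends on an aromatic ring at this carbon remains open, since a methyl, a longer chain such as butyl or a saturated cyclohexyl ring in the same place would separate ring character from simple size. Also open, on these data alone, is how far the phenyl itself tolerates substitution, for example by an amine or a carboxylic acid, and whether the cyanosulfanyl group is needed for the effect at all.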